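The source may hold more compounds than are shown below. What is called first, only, known or untested is meant among the compounds shown, and "the series" means these compounds.

Measured so far:
compound 1 `COc1ccc(-c2cc(-c3ccc(S(=O)(=O)NC4CC4)cc3)cnc2N)cn1`, 2.7
compound 2 `COc1ccc(-c2cc(-c3ccc(-n4cccn4)cc3)cnc2N)cn1`, 3.1
compound 3 `COc1ccc(-c2cc(-c3ccc(C(N)=O)cc3)cnc2N)cn1`, 1.7

In a physicochemical assay for lipophilicity, at pH 7.4 (a lower number here means a more polar compound, a higher number a more lipophilic compound), compound 3 stands lowest of the three measured values: a number 1.00 log units lower from compound 1 to compound 3 (beyond the scatter), and a number 1.40 log units lower from compound 2 to compound 3 (beyond the scatter). Compound 4 `COc1ccc(-c2cc(-c3ccc(C(=O)N(C)C)cc3)cnc2N)cn1` differs from compound 3 by dimethylamino in place of amino on a carbonyl carbon. Among the compounds with values here, none of the measured steps touches this position in the same way; each of them exchanges the whole group on the aromatic carbon, as in a number 0.40 log units higher from compound 1 to compound 2 (beyond the scatter), so no step bears on the change directly. The change keeps the carbonyl and takes the hydrogen-bond donor of the carbamoyl away, which in this assay is expected to give a modest rise, a number 0.60 log units higher from compound 3 to compound 4 (beyond the scatter), beyond the scatter. Compound 4 is therefore expected to give 2.3 in this assay, within 1.8 to 2.8.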

Compound 4, distribution coefficient: 2.1
For compound 4 the middle estimate is 0.20 log units above the measured one; measured number inside the range.
By their numbers in this assay, from the lowest: compound 3; then compound 4; then compound 1; then compound 2.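

In this assay the only step shown that keeps the carbonyl, dimethylamino in place of amino on a carbonyl carbon, gives a number 0.40 log units higher from compound 3 to compound 4 (beyond the scatter) and so shows that this position alone moves the number. Replacing the whole group leaves larger gaps, with a number 0.60 log units lower from compound 1 to compound 4 (beyond the scatter) and a number 1.00 log units lower from compound 2 to compound 4 (beyond the scatter) in the same series. No measured evidence explains the step. Open, going by these compounds, is where methylamino or pyrrolidin-1-yl on the same carbonyl carbon would fall in this assay and whether either would stay under compound 1.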